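This account rests on a few compounds, and the source may have more. Where it says the series, first, only, none or still open, it means among the compounds named here.

In a functional assay on DU-145 cells (Homo sapiens) for inhibition, read by trypan blue exclusion, with a stated time of 72 h (a lower number here means a stronger inhibitor, a higher number a weaker inhibitor), compound 3 `Cn1c(=O)c(S(=O)(=O)Nc2ccc(F)cc2)cc2cnc(Nc3ccc4[nH]ccc4c3)nc21` gives 5000 nM, level with compound 1 `Cn1c(=O)c(C(=O)Nc2ccc(F)cc2)cc2cnc(Nc3ccc4[nH]ccc4c3)nc21` at 5000 nM, and together they hold the highest number of the series, while compound 2 `Cn1c(=O)c(S(=O)(=O)c2ccc(O)cc2)cc2cnc(Nc3ccc4[nH]ccc4c3)nc21` gives 250 nM. Compound 4 `Cn1c(=O)c(S(=O)(=O)c2ccc(N)cc2F)cc2cnc(Nc3ccc4[nH]ccc4c3)nc21` carries 4-amino-2-fluorophenyl in place of (4-fluorophenyl)amino on the sulfonyl sulfur (4-amino-2-fluorophenyl in place of (4-fluorophenyl)amino on a sulfonyl sulfur). Like compound 2, it therefore has an aromatic ring bonded directly to that sulfur. The closest evidence is a 20-fold higher number from compound 2 to compound 3 (1.30 log units; beyond the scatter), a large step, matched by a 20-fold lower number from compound 1 to compound 2 (1.30 log units; beyond the scatter), whereas no change at the digits printed from compound 1 to compound 3 (within the scatter). Among the measured compounds shown here, no measured compound shows the effect of the amino and fluoro groups on that ring. A large step toward a lower number is therefore expected in this assay, estimated as a 17-fold lower number from compound 3 to compound 4 (1.22 log units; beyond the scatter). The expected value for compound 4 is 300 nM, within a range of 90 nM to 1200 nM.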

Compound 4, half-maximal inhibitory concentration: 8000 nM
Beside the measured number, compound 4's estimate is 27-fold (1.43 log units) below it; the whole stated range lies below it.
By their numbers in this assay, from the lowest: compound 2; then compounds 1, 3 and 4 (each within the scatter of the next).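

In this assay, a substituted phenyl ring bonded directly to the sulfonyl sulfur does not by itself bring a low number: replacing 4-hydroxyphenyl with 4-amino-2-fluorophenyl gives a large loss (a 32-fold higher number from compound 2 to compound 4 (1.51 log units; beyond the scatter)). Compound 4 instead stays within the scatter of the sulfamoyl and carbamoyl compounds (a 1.6-fold higher number from compound 3 to compound 4 (0.20 log units; within the scatter); a 1.6-fold higher number from compound 1 to compound 4 (0.20 log units; within the scatter)). Nothing available here accounts for this result. On these data alone, whether the amino group, the fluoro group or both go with the higher number stays open. So does how a plain phenyl or a methoxyphenyl on that sulfur would read.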